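Sulfonyl sulfur change: 1,2,3,4-tetrahydroisoquinolin-2-yl in compound 4

The source may hold more compounds than are shown below. What is called first, only, known or untested is meant among the compounds shown, and "the series" means these compounds.

In an ADME assay on the whole organism (Mus musculus) for pharmacokinetics, at a dose of 1 mg/kg by the intravenous route (a higher number here means that more of the compound sits outside the plasma, a lower number that more of the compound stays in the plasma), compound 1 (`CN(Cc1ccccc1)S(=O)(=O)c1ccc(NC(=O)NCc2ccncc2)cc1`) gives 1.37 L/kg and serves as the reference point for this step. Compound 2 (`O=C(NCc1cn[nH]c1)Nc1ccc(S(=O)(=O)c2ccccc2)cc1`) gives 1.12 L/kg and sits within the scatter of compound 1, so the two cannot be separated on these numbers. Compound 3 (`O=C(NCc1cnco1)Nc1ccc(S(=O)(=O)c2cccc(OC(F)(F)F)c2)cc1`) gives 0.58 L/kg and lies lower than compound 1, beyond the scatter. Among the measured compounds shown here, these three compounds differ from one another in more than one place, so no measured pair isolates a single change.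

Compound 4 (`O=C(NCc1ccncc1)Nc1ccc(S(=O)(=O)N2CCc3ccccc3C2)cc1`) keeps the core of compound 1 and carries 1,2,3,4-tetrahydroisoquinolin-2-yl in place of benzyl(methyl)amino on a sulfonyl sulfur. The data hold no direct measurement of this exchange, and the counted difference between the two groups is small, with no net charge on either. No step beyond the scatter is therefore expected in this assay, and the expectation stays anchored on compound 1 at 1.37 L/kg as the closest measured structure. The estimated step, a 1.1-fold lower number from compound 1 to compound 4 (0.06 log units; within the scatter), is expected to lie within the scatter. Compound 4 is estimated at 1.2 L/kg (expected range 0.7 L/kg to 2.1 L/kg).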

Compound 4, volume of distribution: 0.6 L/kg
For compound 4 the middle estimate is 2.0-fold (0.30 log units) above the measured one; measured number outside the range, below it.
By their numbers in this assay, from the lowest: compounds 3, 4, 2 and 1 (each within the scatter of the next, the first and the last beyond it).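

In this assay, among the compounds shown here, 1,2,3,4-tetrahydroisoquinolin-2-yl in place of benzyl(methyl)amino on a sulfonyl sulfur gives a 2.3-fold lower number from compound 1 to compound 4 (0.36 log units; beyond the scatter), the first reading that isolates a single change. This position is therefore not silent in this measurement: the step appears although the exchange leaves the counted hydrogen-bond donors, hydrogen-bond acceptors and net charge as they were, and the visible structural difference is the added six-membered non-aromatic ring with 1 hetero atom. Nothing available here gives a measured basis for explaining the step.

One pair cannot show whether the step belongs to this particular ring or would appear with other groups on the sulfonyl sulfur, such as dimethylamino or an amine carrying a longer chain, with the rest of compound 1 held constant. On these data alone, compounds 2 and 3 differ from compound 4 in more than one place, so whether the same exchange gives a step of similar size on another core remains open.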